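Bromo for methyl on the core of compound 3

A few compounds are considered here, and "the series" means these few. Any claim that something is new, unique, unknown or untested is made for them only; others in the source may bear on it.

Within the data shown here, compound 3 `Cc1cccc2c1oc(=O)n2C(=O)NCCCCc1ccccc1` carries the lowest number of the three measured so far: in an assay on HEK293 cells for inhibition of acid ceramidase (Homo sapiens), with a stated time of 10 min (a higher number here means a weaker inhibitor, a lower number a stronger inhibitor), compound 3 gives 23 nM. Compound 1 `O=C(NCCCCc1ccccc1)n1c(=O)oc2ccccc21`, the parent without a substituent on the core, gives 64 nM in this assay, and compound 2 `O=C(NCCCCc1ccc(F)cc1)n1c(=O)oc2ccccc21` gives 75 nM. Among the measured compounds shown here, the step of a 2.8-fold lower number from compound 1 to compound 3 (0.44 log units; beyond the scatter) is the only one that touches the core; the step of a 1.2-fold higher number from compound 1 to compound 2 (0.07 log units; within the scatter) concerns a different part of the molecule and is within the scatter.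

Compound 4 `O=C(NCCCCc1ccccc1)n1c(=O)oc2c(Br)cccc21` differs from compound 3 by bromo in place of methyl on an aromatic carbon. For the measured compounds named here, no measured pair swaps bromo for methyl anywhere, so the only guidance is the step of a 2.8-fold lower number from compound 1 to compound 3 (0.44 log units; beyond the scatter), which shows that putting a substituent at this place on the core can lower the number modestly. Whether bromo holds that gain, or gives it back, cannot be read from these three compounds alone; the safest reading is that compound 4 lands near compound 3. The step of a 1.3-fold higher number from compound 3 to compound 4 (0.12 log units; within the scatter) is therefore expected to stay within the scatter. Compound 4 is estimated at 30 nM in this assay, with a range from 12 nM to 80 nM.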

Compound 4, half-maximal inhibitory concentration: 18 nM
For compound 4 the middle estimate is 1.7-fold (0.22 log units) above the measured one; the measured number falls inside the stated range.
By their numbers in this assay, from the lowest: compounds 4 and 3 (each within the scatter of the next); then compounds 1 and 2 (each within the scatter of the next).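

In this assay this aromatic carbon of the core takes bromo as readily as methyl: the swap gives a 1.3-fold lower number from compound 3 to compound 4 (0.11 log units; within the scatter) and so does not separate the two groups. Bromo in place of hydrogen gives a 3.6-fold lower number from compound 1 to compound 4 (0.55 log units; beyond the scatter) and thus joins a 2.8-fold lower number from compound 1 to compound 3 (0.44 log units; beyond the scatter) as a second substituent at this place with a step beyond the scatter from the unsubstituted parent; the lower number is therefore not tied to methyl alone, although this rests on compound 3 and compound 4 only, with no compound shown going against it. Nothing measured here gives a reason for these steps.

Still open, going by these compounds, is whether the same carbon accepts a methoxy group, an amine or a carboxylic acid as it does methyl and bromo, and whether a substituent on the other aromatic carbons of the core lowers the number at all. Also open, on these data alone, is whether the lower number from bromo or methyl persists with a shorter or longer chain on the urea nitrogen, or with the fluoro on the terminal ring of compound 2.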